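Benzothiazole for Benzoxazole on the Sulfonyl Sulfur

The compounds below may be only part of what the source reports. "The series", "measured", "known", "first", "only" and "open" are said of these compounds alone.

compound 1, `CC(C)C1=CC[C@H](C(=O)O)[C@@]12C=CC(=O)CC2`: > 90000 nM
compound 2, `CC(C)C1=CC[C@H](CS(=O)(=O)c2nc3ccccc3o2)[C@@]12C=CC(=O)CC2`: > 90000 nM

Both measured compounds were tested in an ADME assay on BJ cells (Homo sapiens) for cytotoxicity, with a stated time of 72 h; a lower number here means that less compound is needed, a higher number that more compound is needed for the effect. Compound 1 gives a value that is a limit of the assay rather than a number. Compound 2 likewise sits at the limit of > 90000 nM in this assay, at which 2 of the 2 values shown sit. Its position on the numbers shown is therefore only a boundary, and no step between measured compounds can be read off.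

Compound 3, `CC(C)C1=CC[C@H](CS(=O)(=O)c2nc3ccccc3s2)[C@@]12C=CC(=O)CC2`, differs from compound 2 in one place: 1,3-benzothiazol-2-yl in place of 1,3-benzoxazol-2-yl on a sulfonyl sulfur. Among the compounds with values here, with no measured step to lean on, the expectation for this assay rests on the structural change alone, and no move beyond the usual scatter is expected; the step from compound 2 to compound 3 is expected to be a step that the limit leaves unreadable from compound 2 to compound 3. Compound 3 is accordingly estimated at 100000 nM, within a range from 30000 nM to 300000 nM, and the assay is expected most likely to report a limit again.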

Compound 3, half-maximal effective concentration: > 90000 nM
Compound 3 ended at the assay's limit; the forecaster's own chance of this, stated with the estimate: 80%; the middle value is on the limit's open side.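

Compound 3 gives > 90000 nM, which is a limit and not a number. No step from compound 2 to compound 3 can be read: the limit of > 90000 nM in this assay, at which 3 of the 3 values shown sit.

The compounds shown leave open whether 1,3-benzothiazol-2-yl and 1,3-benzoxazol-2-yl differ at all at higher concentrations.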